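Three aryl variants at the assay limit, and a dichloro fourth

The source may report more compounds than this note shows. Statements on the series, on what has been measured and on what is new or still open speak of the compounds shown alone.

Compound 1 `COc1ccccc1NC(=O)N[C@@H]1C2CCN(CC2)[C@@H]1Cc1cccnc1` reaches only the limit > 10000 nM in an assay on a protein complex for binding affinity to Neuronal acetylcholine receptor; alpha4/beta2 (Homo sapiens); on this read-out higher numbers stand for weaker inhibition and lower numbers for stronger inhibition.
Compound 2 `COc1ccc(NC(=O)N[C@@H]2C3CCN(CC3)[C@@H]2Cc2cccnc2)c(OC)c1` likewise returns only the limit > 10000 nM in this assay.
Compound 3 `CSc1ccc(NC(=O)N[C@@H]2C3CCN(CC3)[C@@H]2Cc2cccnc2)cc1` also gives only the limit > 10000 nM in this assay.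

Compound 3 thus stands where every measured value stands, at the limit of > 10000 nM in this assay, at which 3 of the 3 values shown sit. The steps a step that the two limits leave unreadable from compound 1 to compound 2 and a step that the two limits leave unreadable from compound 1 to compound 3 are both unreadable and so bound nothing. They offer no guide to the change from compound 3 to compound 4 `O=C(Nc1ccc(Cl)c(Cl)c1)N[C@@H]1C2CCN(CC2)[C@@H]1Cc1cccnc1`, which is 3,4-dichlorophenyl in place of 4-(methylsulfanyl)phenyl on an amide-type nitrogen. With no readable step to lean on, and all three measured compounds sitting at the limit, the expectation for compound 4 is another limit rather than a number, so the estimated step of a number no higher from compound 3 to compound 4 (the limit leaves the size open) is none beyond the scatter. Compound 4 is therefore expected at 10000 nM, within 3000 nM to 30000 nM.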

Compound 4, inhibition constant: > 10000 nM
Compound 4: no number, only a limit (the forecaster's own chance of this, stated with the estimate: 75%); the middle value sits exactly at the limit.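

In this assay, among the compounds shown here, compound 4 gives only the limit > 10000 nM and no number, so no step from compound 1 or compound 3 to compound 4 can be read. The compounds shown leave open whether any aryl group on the shared core reaches a number in this assay at all.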